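Homologation of the acetyl group on compound 3

This account rests on a few compounds, and the source may have more. Where it says the series, first, only, none or still open, it means among the compounds named here.

Measured compounds:
Compound 1, `O=C(NCc1ccc(S(=O)(=O)c2cncc(C(F)(F)F)c2)cc1)N1Cc2ccncc2C1`, 15 nM
Compound 2, `O=C(NCc1ccc(S(=O)(=O)C2CCOCC2)cc1)N1Cc2ccncc2C1`, 26 nM
Compound 3, `CC(=O)N1CCC(S(=O)(=O)c2ccc(CNC(=O)N3Cc4ccncc4C3)cc2)CC1`, 83 nM

All three share one core and differ only in the group on the sulfonyl sulfur, read in an assay on isolated protein for inhibition of Nicotinamide phosphoribosyltransferase (Homo sapiens), read by mass spectrometry, with stated times of 15 min and 30 min; a lower number here means a stronger inhibitor, a higher number a weaker inhibitor. Compound 3 gives the highest number of the three: it stands a 3.2-fold higher number from compound 2 to compound 3 (0.50 log units; beyond the scatter) and a 5.5-fold higher number from compound 1 to compound 3 (0.74 log units; beyond the scatter), while the gap a 1.7-fold higher number from compound 1 to compound 2 (0.24 log units; within the scatter) is within the scatter.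

Compound 4, `CCC(=O)N1CCC(S(=O)(=O)c2ccc(CNC(=O)N3Cc4ccncc4C3)cc2)CC1`, is the next step: methyl in place of hydrogen on a saturated chain carbon bound to a carbonyl carbon. Within the data shown here, none of the measured steps bears directly on it; each of them exchanges the whole group on the sulfonyl sulfur, whereas this change only lengthens the chain on the nitrogen of the 1-acetylpiperidin-4-yl group by one carbon. Among the measured compounds shown here, no compound tests such a homologation, so there is no measured basis for a shift in either direction, and a step within the scatter is expected.

For compound 4 in this assay the estimated step is a 1.1-fold higher number from compound 3 to compound 4 (0.04 log units; within the scatter), giving an expected value of 90 nM with a range from 40 nM to 200 nM.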

Compound 4, half-maximal inhibitory concentration: 27 nM
The estimate for compound 4 lay 3.3-fold (0.52 log units) above the measured number, outside the stated range (below it).
By their numbers in this assay, from the lowest: compounds 1, 2 and 4 (each within the scatter of the next); then compound 3.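

In this assay, among these compounds, the change from acetyl to propanoyl is the first that leaves the rest of the group on the sulfonyl sulfur in place, and this one added methyl gives a 3.1-fold lower number from compound 3 to compound 4 (0.49 log units; beyond the scatter), so the chain on this nitrogen responds to a single carbon. With 1-propanoylpiperidin-4-yl on the sulfonyl sulfur, the steps of a 1.0-fold higher number from compound 2 to compound 4 (0.02 log units; within the scatter) and a 1.8-fold higher number from compound 1 to compound 4 (0.26 log units; within the scatter) both lie within the scatter, so this group no longer stands apart from oxan-4-yl or 5-(trifluoromethyl)pyridin-3-yl as 1-acetylpiperidin-4-yl does. No supporting data bear on this step.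

A single step cannot show whether a longer chain such as butanoyl would continue the trend. Also open, on these data alone, is how a branched isobutyryl or a cyclopropanecarbonyl group would compare with propanoyl.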